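From Diethylamino to Pyrrolidin-1-yl on the Same Chain

This account rests on a few compounds, and the source may have more. Where it says the series, first, only, none or still open, it means among the compounds named here.

Measured so far in a functional assay on HepG2 cells (Homo sapiens) for cytotoxicity, read by MTT assay, with a stated time of 48 h; a lower number here means a stronger inhibitor, a higher number a weaker inhibitor:
Compound 1 `CC1=NN(C(=O)c2ccc(C)cc2)C(c2ccccc2O)C1`: 11300 nM
Compound 2 `CC1=NN(C(=O)COc2ccc(Cl)cc2)C(c2cc(Br)cc(Br)c2O)C1`: "not active" (no number reported)
Compound 3 `CCN(CC)CC(=O)N1N=C(C)CC1c1ccccc1O`: 51600 nM

Only two of these compounds have a number in this assay, and compound 3 holds the higher one. Going by the values given here, its nearest neighbour is compound 1, while compound 2 gives no number and so offers no measured step.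

Compound 4 `CC1=NN(C(=O)CN2CCCC2)C(c2ccccc2O)C1` keeps the core of compound 3 and differs from it in one place: pyrrolidin-1-yl in place of diethylamino on a saturated chain carbon bound to a carbonyl carbon. Pyrrolidin-1-yl stands in place of diethylamino on a saturated chain carbon bound to a carbonyl carbon.

Among the compounds with values here, only one measured step bears on this change. It is a 4.6-fold higher number from compound 1 to compound 3 (0.66 log units; beyond the scatter), a modest step beyond the scatter, in which (diethylamino)methyl replaced 4-methylphenyl on a carbonyl carbon. Within the data shown here, that exchange reaches further than the one considered here, and no measured step replaces diethylamino with another group. The size of that step therefore serves only as an upper guide, and no shift beyond the scatter is expected. The expected change is a 1.3-fold lower number from compound 3 to compound 4 (0.11 log units; within the scatter). In this assay the estimate for compound 4 is 40000 nM, with an expected range from 15000 nM to 100000 nM.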

Compound 4, half-maximal inhibitory concentration: 5540 nM
For compound 4 the middle estimate is 7.2-fold (0.86 log units) above the measured one; measured number outside the range, below it.
By their numbers in this assay, from the lowest: compound 4; then compound 1; then compound 3.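

In this assay, the step of a 9.3-fold lower number from compound 3 to compound 4 (0.97 log units; beyond the scatter) shows that this position, on a saturated chain carbon bound to a carbonyl carbon, can respond clearly to a change that leaves the heavy-atom count and the hydrogen-bond donor and acceptor counts as they were. Diethylamino and pyrrolidin-1-yl carry the same carbon and nitrogen atoms, and the one difference counted between them is the five-membered non-aromatic ring of the entering group. The comparison with 4-methylphenyl on a carbonyl carbon also changes: a 4.6-fold higher number from compound 1 to compound 3 (0.66 log units; beyond the scatter) had pointed to a higher number, whereas a 2.0-fold lower number from compound 1 to compound 4 (0.31 log units; beyond the scatter) points to a lower one, so among these compounds an amine-bearing methyl group in that place does not move the number in one fixed direction.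

Nothing available here explains the difference between the two amines. On these data alone, it remains open whether piperidin-1-yl, morpholin-4-yl or dimethylamino on the same chain would give a number closer to that of compound 3 or compound 4, and whether pyrrolidin-1-yl would keep its standing on a longer chain.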